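The source may report more compounds than this note shows. Statements on the series, on what has been measured and on what is new or still open speak of the compounds shown alone.

Of the compounds shown here, three built on one shared core have been tested in a functional assay on K562 cells (Homo sapiens) for inhibition; a higher number here means a weaker inhibitor, a lower number a stronger inhibitor. Compound 1 `O=C1C=CC(OCC(F)(F)F)N1c1ccc(C(F)(F)F)cc1` gives 13100 nM, and compound 2 `Cc1ccc(N2C(=O)C=CC2OCC(F)(F)F)cc1` gives 7140 nM. Compound 3 `O=C1C=CC(OCC(F)(F)F)N1c1ccccc1` gives 24600 nM, the highest of the three numbers: against compound 1 the gap stays within the scatter, against compound 2 it goes beyond it. Two measured steps lead into compound 3 and both exchange the same aromatic substituent for hydrogen: a 1.9-fold higher number from compound 1 to compound 3 (0.27 log units; within the scatter) and a 3.4-fold higher number from compound 2 to compound 3 (0.54 log units; beyond the scatter). Compound 4 `CC(C)(C)c1ccc(N2C(=O)C=CC2OCC(F)(F)F)cc1` reverses that direction, carrying (tert-butyl in place of hydrogen on an aromatic carbon), para to a large group; the group that enters has 4 carbon atoms, no ring and no hydrogen-bond donors or acceptors. Going by the values given here, the nearest precedent is the methyl step, which was modest and beyond the scatter, so a drop of similar, possibly somewhat larger size is expected for a larger carbon group, in this assay. Compound 4 is therefore estimated at 6500 nM, with a range from 2500 nM to 18000 nM. This estimate means an expected 3.8-fold lower number from compound 3 to compound 4 (0.58 log units; beyond the scatter).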

Compound 4, half-maximal inhibitory concentration: 70 nM
Compound 4: the middle estimate sits 93-fold (1.97 log units) above what was measured, outside the stated range (below it).
By their numbers in this assay, from the lowest: compound 4; then compounds 2, 1 and 3 (each within the scatter of the next, the first and the last beyond it).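

In this assay, this aromatic carbon proves able to carry a change far larger than the small groups suggested: tert-butyl in place of hydrogen gives a 350-fold lower number from compound 3 to compound 4 (2.55 log units; beyond the scatter), while trifluoromethyl and methyl had moved the number much less. The large drop is also specific to tert-butyl among the groups compared here, since it stands well apart from both other substituents, with a 100-fold lower number from compound 2 to compound 4 (2.01 log units; beyond the scatter) and a 190-fold lower number from compound 1 to compound 4 (2.27 log units; beyond the scatter). No measurement at hand offers a reason for this jump.

The compounds shown leave open whether the branched shape of tert-butyl or simply its carbon count matters, which isopropyl, cyclohexyl or a longer chain such as n-butyl could help to separate. As far as these compounds go, it also remains open how an amine or a carboxylic acid at this carbon would compare.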